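A few compounds are considered here, and "the series" means these few. Any claim that something is new, unique, unknown or untested is made for them only; others in the source may bear on it.

Among the compounds with values here, the two compounds measured so far share a chromone-carboxylic-acid core bearing an amide on the ring. Compound 1, `COc1ccc(C(=O)Nc2cc(Br)cc3c(=O)cc(C(=O)O)oc23)c(Cl)c1`, was tested in an assay on CHO cells for agonist activity at G protein-coupled receptor GPR35 (Rattus norvegicus), read by a beta-galactosidase reporter and beta-arrestin recruitment, with a stated time of 90 min (a higher number here means that more compound is needed for the effect, a lower number that less compound is needed), where compound 1 gives 4170 nM. Compound 2, `COc1ccc(C(=O)Nc2cc(F)cc3c(=O)cc(C(=O)O)oc23)cc1`, gives 1760 nM in this assay. Of the two numbers, that of compound 1 is the higher; the gap to compound 2 lies beyond the usual scatter of such measurements, so compound 2 needs less compound for the same effect than compound 1 does.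

Compound 3, `N#Cc1ccc(C(=O)Nc2cc(Br)cc3c(=O)cc(C(=O)O)oc23)cc1`, has not yet been measured in this assay. It differs from compound 1 in one place: 4-cyanophenyl in place of 2-chloro-4-methoxyphenyl on a carbonyl carbon. Within the data shown here, no pair of measured compounds differing in exactly this way is available, so the size of the step cannot be read from the measured data. The two measured values show that changes on the aryl amide leave the numbers in the low-micromolar region, and compound 3 is therefore expected to stay near compound 1, with a step of a 1.4-fold lower number from compound 1 to compound 3 (0.14 log units; within the scatter) that may well fall within the scatter. The estimate for compound 3 in this assay is 3000 nM, with a range from 800 nM to 12000 nM.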

Compound 3, half-maximal effective concentration: 2260 nM
For compound 3 the middle estimate is 1.3-fold (0.12 log units) above the measured one; low and high end bracket the measured number.
By their numbers in this assay, from the lowest: compounds 2, 3 and 1 (each within the scatter of the next, the first and the last beyond it).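

In this assay, within the data shown here, compound 1 and compound 3 form the first pair in this set that differs in one place, a change of the group on a carbonyl carbon whose other neighbour is an amide-type nitrogen. The step is a 1.8-fold lower number from compound 1 to compound 3 (0.27 log units; within the scatter) and so gives no measurable separation between the 2-chloro-4-methoxyphenyl and 4-cyanophenyl groups. At this position, with the bromine-bearing core held constant, the chlorine and methoxy groups can therefore leave and a nitrile can enter with no difference that this assay can resolve, although this single pair establishes no general rule.

The compounds shown leave open whether this insensitivity extends to quite different groups at the same place, such as an aminomethylphenyl ring, a carboxyphenyl ring or an unbranched hexyl chain, and whether the same exchange would read alike on a core carrying fluorine instead of bromine. Nothing available here explains why these two aryl groups give values that cannot be told apart.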